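Aryl swap at the saturated ring carbon of the core

A few compounds are considered here, and "the series" means these few. Any claim that something is new, unique, unknown or untested is made for them only; others in the source may bear on it.

Among the measured compounds shown here, compound 2 `Cc1c(F)cccc1C1C(=O)N(C)c2cnc(Nc3ccc(S(N)(=O)=O)cc3)nc2N1C` gives the highest of the two numbers so far: in an assay on Sf9 cells for inhibition of serine/threonine-protein kinase 4 (Homo sapiens), read by luminescence and ADP-Glo, with a stated time of 1 h, in the presence of a further agent that is not named here (a higher number here means a weaker inhibitor, a lower number a stronger inhibitor), compound 2 gives 419 nM, while compound 1 `CN1C(=O)C(c2cccc(F)c2)N(C)c2nc(Nc3ccc(S(N)(=O)=O)cc3)ncc21` gives 134 nM. For the measured compounds named here, the one measured step, a 3.1-fold higher number from compound 1 to compound 2 (0.50 log units; beyond the scatter), is the only comparison in hand.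

Compound 3 `CN1C(=O)C(c2cccs2)N(C)c2nc(Nc3ccc(S(N)(=O)=O)cc3)ncc21` differs from compound 2 as follows: thiophen-2-yl in place of 3-fluoro-2-methylphenyl on a saturated ring carbon. Going by the values given here, no measured pair shows this exact exchange, so the expectation rests on the one step available. That step, a 3.1-fold higher number from compound 1 to compound 2 (0.50 log units; beyond the scatter), shows that adding the methyl to the aromatic carbon raised the number; compound 3 carries neither that methyl nor the fluorine, so the number is expected to move back toward the value of compound 1 rather than further up. Since the five-membered ring is new to the series, the size of the change is uncertain, and a modest drop in the number, with wide bounds, is the estimate.

For compound 3 in this assay the expected value is 200 nM, with a range from 70 nM to 600 nM.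

The step implied from compound 2 to compound 3 is expected to be a 2.1-fold lower number from compound 2 to compound 3 (0.32 log units; beyond the scatter).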

Compound 3, half-maximal inhibitory concentration: 88 nM
Compound 3: middle estimate off by 2.3-fold (0.36 log units), on the high side; measured number inside the range.
By their numbers in this assay, from the lowest: compounds 3 and 1 (each within the scatter of the next); then compound 2.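

In this assay the saturated ring carbon takes a five-membered aromatic ring with one sulfur as well as a six-membered aromatic ring of carbon only: the exchange of 3-fluorophenyl for thiophen-2-yl gives a 1.5-fold lower number from compound 1 to compound 3 (0.18 log units; within the scatter), so these two groups cannot be told apart at this position. Set against 3-fluoro-2-methylphenyl, the same thiophen-2-yl gives a 4.8-fold lower number from compound 2 to compound 3 (0.68 log units; beyond the scatter), which leaves compound 2 as the one compound standing apart from the other two, and shows that the aromatic ring here can change size and gain a hetero atom without the number rising. Nothing at hand accounts for this behaviour at the position.

Among the compounds shown here, with only three aromatic groups compared, it remains open whether an aromatic ring is needed on this carbon at all, or whether a saturated group such as cyclohexyl or a plain methyl would serve as well. Also open, from the compounds shown here alone, is how a thiophene carrying a substituent, such as a methyl, an amine or a carboxylic acid, would behave, and whether it would follow the step seen with compound 2.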